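Chain-end thiourea rearrangement in a pyridazinone series

The compounds below may be only part of what the source reports. "The series", "measured", "known", "first", "only" and "open" are said of these compounds alone.

Measured compounds in a functional assay on the whole organism with Rattus norvegicus as the target, at a dose of 100 mg/kg; on this read-out higher numbers stand for more inhibition at the one dose given (going by the name of the read-out) and lower numbers for less inhibition:
Compound 1, `CCC/N=C(/NC#N)NCCCCn1nc(-c2ccccc2)ccc1=O`, gives 26.3%.
Compound 2, `N#CNC(=N)NCCCCCCn1nc(-c2ccccc2)ccc1=O`, gives 20.5%.
Compound 3, `C/N=C(\S)N(C)CCCCn1nc(-c2ccccc2)ccc1=O`, gives 17.5%.

Compound 3 holds the lowest of the three numbers in this assay, yet its distance to compound 2 and to compound 1 is within the scatter, so the three are not separable. Among the measured compounds shown here, the one measured step at the same place, a number 3 percentage points lower from compound 2 to compound 3 (within the scatter), swapped whole groups and still stayed within the scatter.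

Compound 4, `CC/N=C(\S)NCCCCn1nc(-c2ccccc2)ccc1=O`, differs from compound 3 only in how the same atoms are joined: a group of 6 heavy atoms (3 carbon, 2 nitrogen, 1 sulfur; no ring) in place of a group of 6 heavy atoms (3 carbon, 2 nitrogen, 1 sulfur; no ring), on a saturated chain carbon, four bonds along the chain from an aromatic nitrogen. For the measured compounds named here, with the sole comparable step flat, no movement beyond the scatter is expected in this assay, and the step of a number 2.5 percentage points higher from compound 3 to compound 4 (within the scatter) is the estimate. Compound 4 is expected to give 20%, within 8% to 32%.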

Compound 4, a percentage reported as inhibition, in the whole organism at one dose (the size of the read-out at that dose, not a potency): 67.7%
Compound 4: the middle estimate sits 47.7 percentage points below what was measured; measured number outside the range, above it.
By their numbers in this assay, from the lowest: compounds 3, 2 and 1 (each within the scatter of the next); then compound 4.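

In this assay, the same atoms joined differently give a number 50.2 percentage points higher from compound 3 to compound 4 (beyond the scatter), so this position is sensitive to how the chain end is connected, which the earlier flat step did not reveal. The entering group has 2 hydrogen-bond donors where the leaving group has 1, and the other two steps, a number 47.2 percentage points higher from compound 2 to compound 4 (beyond the scatter) and a number 41.4 percentage points higher from compound 1 to compound 4 (beyond the scatter), also exceed the scatter. Nothing available accounts for the rise.

The ethyl group and the added hydrogen-bond donor change together, so their contributions cannot be separated. Going by these compounds, how a propyl group in place of ethyl would read in this assay remains open.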